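Removing the Methyl From the Methoxy Group of Compound 2

A few compounds are considered here, and "the series" means these few. Any claim that something is new, unique, unknown or untested is made for them only; others in the source may bear on it.

Of the compounds shown here, three built on one shared core have been tested in a functional assay on CAKI-1 cells (Homo sapiens) for inhibition, read by sulforhodamine B assay, with a stated time of 48 h; a lower number here means a stronger inhibitor of growth, a higher number a weaker inhibitor of growth. Compound 2 `COc1cc(-c2nn(-c3cccc(NC(=O)Nc4cc(C(F)(F)F)cc(C(F)(F)F)c4)c3)cc2-c2ccncc2)ccc1Cl` gives 993 nM. Compound 3 `COc1cc(-c2nn(-c3cccc(NC(=O)Nc4cccc(C(F)(F)F)c4)c3)cc2-c2ccncc2)ccc1Cl` gives 1030 nM, and compound 1 `O=C(Nc1cccc(-n2cc(-c3ccncc3)c(-c3ccc(Cl)c(O)c3)n2)c1)Nc1cccc(C(F)(F)F)c1` gives 1750 nM. The number for compound 2 is the lowest of the three, but all three sit within the usual scatter of one another, so no real order between them can be claimed.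

Compound 4 `O=C(Nc1cccc(-n2cc(-c3ccncc3)c(-c3ccc(Cl)c(O)c3)n2)c1)Nc1cc(C(F)(F)F)cc(C(F)(F)F)c1` is compound 2 with a single change: hydrogen in place of methyl on an oxygen on an aromatic ring. Among the compounds with values here, only one measured step touches this spot, and it runs the other way, a 1.7-fold lower number from compound 1 to compound 3 (0.23 log units; within the scatter), where a methyl was put on rather than taken off. Read in reverse, it suggests that removing the methyl would at most nudge the number upward by a similar small amount, still within the scatter. The other measured step, a 1.0-fold higher number from compound 2 to compound 3 (0.02 log units; within the scatter), concerns a trifluoromethyl on a different ring and does not bear on this change. Compound 4 is therefore expected to give 1500 nM in this assay, with a range from 700 nM to 3200 nM, which is expected to amount to a 1.5-fold higher number from compound 2 to compound 4 (0.18 log units; within the scatter).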

Compound 4, concentration for 50% growth inhibition: 1010 nM
Compound 4: the middle estimate sits 1.5-fold (0.17 log units) above what was measured; the measured number falls inside the stated range.
By their numbers in this assay, from the lowest: compounds 2, 4, 3 and 1 (each within the scatter of the next).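

In this assay, taking the methyl off this oxygen gives a 1.0-fold higher number from compound 2 to compound 4 (0.01 log units; within the scatter), so the swap from methoxy to hydroxy now has a second reading on a core carrying an extra trifluoromethyl. The two readings of this swap agree: the same change on two cores in this assay, a 1.7-fold lower number (0.23 log units; within the scatter) from compound 1 to compound 3 and a 1.0-fold lower number (0.01 log units; within the scatter) from compound 4 to compound 2, 1.7-fold (0.22 log units) apart, within the scatter of two such steps. Adding that trifluoromethyl to the hydroxy compound gives a 1.7-fold lower number from compound 1 to compound 4 (0.24 log units; within the scatter), and this change also reads alike whether the oxygen carries hydrogen or methyl: the same change on two cores in this assay, a 1.0-fold higher number (0.02 log units; within the scatter) from compound 2 to compound 3 and a 1.7-fold higher number (0.24 log units; within the scatter) from compound 4 to compound 1, 1.7-fold (0.22 log units) apart, within the scatter of two such steps.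

With only hydrogen and methyl shown on this oxygen, it remains open whether a longer chain such as ethyl, or an amine in place of the hydroxy, would shift the number beyond the scatter. All four compounds also lie within the scatter of the next in line, so these steps do not show which groups matter for growth inhibition.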